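This account rests on a few compounds, and the source may have more. Where it says the series, first, only, none or still open, it means among the compounds named here.

Measured in a functional assay on HUVEC cells (Homo sapiens) for inhibition; on this read-out higher numbers stand for weaker inhibition and lower numbers for stronger inhibition:
- Compound 1 `CN(c1ccc(NC(=O)Oc2ccccc2)cc1)c1ccnc(Nc2cccc(CS(C)(=O)=O)c2)n1`: 224 nM
- Compound 2 `CN(c1ccc(NS(=O)(=O)Cc2ccccc2)cc1)c1ccnc(Nc2cccc(CS(C)(=O)=O)c2)n1`: 350 nM
- Compound 3 `CC(=O)c1ccc(NC(=O)Nc2ccc(N(C)c3ccnc(Nc4cccc(CS(C)(=O)=O)c4)n3)cc2)cc1`: 2 nM

Compound 3 has the lowest number of the three. Two large steps lead to it: a 110-fold lower number from compound 1 to compound 3 (2.05 log units; beyond the scatter) and a 180-fold lower number from compound 2 to compound 3 (2.24 log units; beyond the scatter). By contrast, a 1.6-fold higher number from compound 1 to compound 2 (0.19 log units; within the scatter) stays within the scatter.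

Compound 4 `CN(c1ccc(NC(=O)Nc2c(Cl)cccc2Cl)cc1)c1ccnc(Nc2cccc(CS(C)(=O)=O)c2)n1` differs from compound 3 in one place: 2,6-dichlorophenyl in place of 4-acetylphenyl on an amide-type nitrogen. In short, 2,6-dichlorophenyl replaces 4-acetylphenyl on an amide-type nitrogen, so the carbamoyl link stays.

Both large steps installed that link and the 4-acetylphenyl group together, so they cannot show how much the ring alone contributes. Going by the values given here, no measured pair changes only this ring. Compound 4 keeps the link found in compound 3 at 2 nM, so a return to the level of compound 1 at 224 nM is not expected. A moderate loss in this assay seems more likely, and the expected change is a 5.0-fold higher number from compound 3 to compound 4 (0.70 log units; beyond the scatter). For compound 4 the estimate is 10 nM, with an expected range of 2 nM to 60 nM.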

Compound 4, half-maximal inhibitory concentration: 29 nM
Compound 4: the middle estimate sits 2.9-fold (0.46 log units) below what was measured; measured number inside the range.
By their numbers in this assay, from the lowest: compound 3; then compound 4; then compounds 1 and 2 (each within the scatter of the next).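

In this assay, going by these compounds alone, the first pair that changes only the ring on this amide-type nitrogen gives a 15-fold higher number from compound 3 to compound 4 (1.16 log units; beyond the scatter) and so shows that, with the carbamoyl link held fixed, the ring alone has a large effect. A urea-type carbamoyl group without 4-acetylphenyl can still lower the number, as a 7.7-fold lower number from compound 1 to compound 4 (0.89 log units; beyond the scatter) and a 12-fold lower number from compound 2 to compound 4 (1.08 log units; beyond the scatter) show, so the gain over compounds 1 and 2 does not depend on that one ring. No measurement here explains why the two rings differ.

The compounds shown leave open whether the loss comes from removing the acetyl group, adding the two chlorines, or both. A plain phenyl ring on the same nitrogen would help separate these changes, and a ring bearing an amine or a carboxylic acid would test other groups here.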